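Methoxy for methyl at the cytotoxicity limit

A few compounds are considered here, and "the series" means these few. Any claim that something is new, unique, unknown or untested is made for them only; others in the source may bear on it.

In a functional assay on Huh7.5.1 cells (Homo sapiens) for cytotoxicity, read by MTT assay, with a stated time of 72 h (on this read-out higher numbers stand for lower toxicity in this test and lower numbers for higher toxicity in this test), compound 1 (`C=c1[nH]c(=O)/c(=C/c2ccc(C(C)(C)C)cc2)[nH]c1=O`) gives > 20000 nM as its reading, which is a limit and not a number. Compound 2 (`C=c1[nH]c(=O)/c(=C/c2ccc(C)cc2)[nH]c1=O`) gives > 20000 nM as its reading in this assay and this too is a limit and not a number. For the measured compounds named here, compound 2 therefore stands without a number of its own, and the only other value beside it is also a limit (the limit of > 20000 nM in this assay, at which 2 of the 2 values shown sit). Going by the values given here, the one measured step that bears on what follows (a step that the two limits leave unreadable from compound 1 to compound 2) put methyl in place of tert-butyl on an aromatic carbon and leaves no size to carry forward. Compound 3 (`C=c1[nH]c(=O)/c(=C/c2ccc(OC)cc2)[nH]c1=O`) carries methoxy in place of methyl on an aromatic carbon. The expectation rests on compound 2 with its limit (> 20000 nM) and no step beyond the usual scatter is expected in this assay in either direction. The estimated step that the limit leaves unreadable from compound 2 to compound 3 is expected to be nominal only. For compound 3 the estimate is 25000 nM with an expected range from 12000 nM to 50000 nM and a reading that is again only a limit is the expected outcome.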

Compound 3, half-maximal cytotoxic concentration: > 20000 nM
Compound 3: only a limit was reported (the forecaster's own chance of this, stated with the estimate: 85%); the middle value does not contradict the limit.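

No new step can be read from compound 2 to compound 3 or from compound 1 to compound 3 in this assay, since each reading is a limit and not a number: the limit of > 20000 nM in this assay, at which 3 of the 3 values shown sit. The compounds shown leave open whether tert-butyl, methyl and methoxy differ at all, and at what concentration any of the three would become toxic.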